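A Bulkier Cyclic Amine on the Thiocarbonyl Carbon

This account rests on a few compounds, and the source may have more. Where it says the series, first, only, none or still open, it means among the compounds named here.

Of the compounds shown here, three sharing one core have been measured in a functional assay on MGC-803 cells (Homo sapiens) for antiproliferative activity, read by CCK-8 assay, with a stated time of 72 h, tested at 2 uM; on this read-out lower numbers stand for a weaker effect and higher numbers for a stronger effect at the one concentration tested. Within the data shown here, compound 1 `Nc1ccccc1NC(=O)c1ccc(CSC(=S)N2CCN(Cc3ccccn3)CC2)cc1` gives 23.4%, and compound 2 `Nc1ccccc1NC(=O)c1ccc(CSC(=S)N2CCN(c3ccc(Cl)cc3)CC2)cc1` gives 15%; the one step between them, a number 8.4 percentage points lower from compound 1 to compound 2 (within the scatter), is within the scatter. Compound 3 `CCN(Cc1ccncc1)C(=S)SCc1ccc(C(=O)Nc2ccccc2N)cc1` gives 71.6% and stands highest of the three, clear of both compound 1 and compound 2 by gaps beyond the scatter.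

Compound 4 `Nc1ccccc1NC(=O)c1ccc(CSC(=S)N2CCCc3ccccc32)cc1` differs from compound 3 in a single place: 1,2,3,4-tetrahydroquinolin-1-yl in place of ethyl((pyridin-4-yl)methyl)amino on a thiocarbonyl carbon. Among the measured compounds shown here, no measured step bears directly on this change; the only step available, a number 8.4 percentage points lower from compound 1 to compound 2 (within the scatter), alters a group on an amine nitrogen in a ring and is within the scatter. What the numbers do show is that compound 3 sits far above compound 1 and compound 2, and that compound 4 no longer carries the ethyl((pyridin-4-yl)methyl)amino group of compound 3. The author therefore expects a step downward beyond the scatter, a number 36.6 percentage points lower from compound 3 to compound 4 (beyond the scatter), and estimates compound 4 at 35%, within 12% to 62%.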

Compound 4, a percentage reported as inhibition, at one concentration (the size of the read-out at that concentration, not a potency): 38.5%
Estimate against measurement, compound 4: 3.5 percentage points below; low and high end bracket the measured number.
By their numbers in this assay, from the lowest: compounds 2 and 1 (each within the scatter of the next); then compound 4; then compound 3.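

In this assay, placing 1,2,3,4-tetrahydroquinolin-1-yl instead of ethyl((pyridin-4-yl)methyl)amino on the thiocarbonyl carbon gives a number 33.1 percentage points lower from compound 3 to compound 4 (beyond the scatter), so this position, unlike the ring amine nitrogen changed between compounds 1 and 2, has a single-place step beyond the scatter. The two groups have the same heavy-atom count, so the step cannot be tied to that count; they differ instead in their rings and in the hydrogen-bond acceptor, which only the leaving group carries. Nothing available explains the size of this step.

Among these compounds, the single change alters several features at once, so the pyridine nitrogen and the ring closure cannot be separated. As far as these compounds go, it remains open how a benzyl group in place of the (pyridin-4-yl)methyl group, or a propyl chain in place of the ethyl group, would read out at this position.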